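The source may report more compounds than this note shows. Statements on the series, on what has been measured and on what is new or still open speak of the compounds shown alone.

Compound 1 `CN1CCN(c2ccc(C3=NN(S(=O)(=O)c4ccc(C(F)(F)F)cc4)C(c4ccc(N(C)C)cc4)C3)cc2)CC1` and compound 2 `CN1CCN(c2ccc(C3=NN(S(=O)(=O)c4ccc(C#N)cc4)C(c4ccc(N(C)C)cc4)C3)cc2)CC1` share one core. In a functional assay on MDA-MB-231 cells (Homo sapiens) for inhibition, read by sulforhodamine B assay, tested at 10 uM (a lower number here means less inhibition, a higher number more inhibition at the concentration tested (going by the name of the read-out)), compound 1 gives 12.1%, while compound 2 gives 99.8%; the step of a number 87.7 percentage points higher from compound 1 to compound 2 (beyond the scatter) goes with the change (cyano in place of trifluoromethyl on an aromatic carbon). Compound 3 `CN(C)c1ccc(C2CC(c3ccc(-n4cncn4)cc3)=NN2S(=O)(=O)c2ccc(C(F)(F)F)cc2)cc1` differs from compound 1 in its core by 1H-1,2,4-triazol-1-yl in place of 4-methylpiperazin-1-yl on an aromatic carbon; in this assay compound 3 gives 15.3%, a step of a number 3.2 percentage points higher from compound 1 to compound 3 (within the scatter). Compound 4 `CN(C)c1ccc(C2CC(c3ccc(-n4cncn4)cc3)=NN2S(=O)(=O)c2ccc(C#N)cc2)cc1`, not yet measured, differs from compound 3 by cyano in place of trifluoromethyl on an aromatic carbon, the same change as from compound 1 to compound 2, at the same place. Among the measured compounds shown here, for compound 4 a step of a number 74.7 percentage points higher from compound 3 to compound 4 (beyond the scatter) is expected, resting on the single earlier instance a number 87.7 percentage points higher from compound 1 to compound 2 (beyond the scatter) and on the starting point of compound 3, 15.3%. The estimate for compound 4 is 90%, between 55% and 100%.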

Compound 4, a percentage reported as inhibition, at one concentration (the size of the read-out at that concentration, not a potency): 32.8%
Beside the measured number, compound 4's estimate is 57.2 percentage points above it, and the stated range ends above it.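

In this assay, cyano in place of trifluoromethyl raises the number on both cores, with a number 17.5 percentage points higher from compound 3 to compound 4 (beyond the scatter), but the size of the step does not carry over: the same change on two cores in this assay, a number 87.7 percentage points higher (beyond the scatter) from compound 1 to compound 2 and a number 17.5 percentage points higher (beyond the scatter) from compound 3 to compound 4, 70.2 percentage points apart, beyond the scatter of two such steps

Read the other way, 1H-1,2,4-triazol-1-yl in place of 4-methylpiperazin-1-yl gives a number 67 percentage points lower from compound 2 to compound 4 (beyond the scatter), so its effect depends on the group on the other aromatic ring: the same change on two cores in this assay, a number 3.2 percentage points higher (within the scatter) from compound 1 to compound 3 and a number 67 percentage points lower (beyond the scatter) from compound 2 to compound 4, 70.2 percentage points apart, beyond the scatter of two such steps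

These four compounds show that the two changes do not add up, but not what lies behind this, and they say nothing of how the change would behave on a third core.

Open, from the compounds shown here alone, is whether an open-chain amine in place of 4-methylpiperazin-1-yl would keep a cyano compound near compound 2 or near compound 4. Going by these compounds, a carboxylic acid in place of cyano is equally open.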